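Enantiomer of compound 2 in HEp-2 cytotoxicity

The compounds below may be only part of what the source reports. "The series", "measured", "known", "first", "only" and "open" are said of these compounds alone.

The series consists of two measured compounds and one unmeasured one. Compound 1 `CC[C@@H](CCn1cncn1)c1ccc(F)cc1` and compound 2 `CCC[C@H](CCn1cncn1)c1ccc(F)cc1` have both been tested in an ADME assay on HEp-2 cells (Homo sapiens) for cytotoxicity, read by MTT assay, with a stated time of 3 days; a lower number here means that less compound is tolerated, a higher number that more compound is tolerated. In this assay compound 1 gives 90.3 ug/mL. In this assay compound 2 gives 39.3 ug/mL, the lowest of the two numbers; its nearest neighbour is compound 1, and the gap between the two lies beyond the scatter. For the measured compounds named here, no pair of measured compounds differs in only one place, so no single structural step has yet been characterised by the data.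

Compound 3 `CCC[C@@H](CCn1cncn1)c1ccc(F)cc1` is the next compound for this assay. Relative to compound 2 it shows (the two compounds have the same atoms and bonds and differ only in configuration as drawn: 1 of 1 stereo elements differ; a stereocentre at a saturated chain carbon is drawn R in compound 2 and S in compound 3). Going by the values given here, with no comparable step measured, the expectation is that the change from compound 2 to compound 3 gives no step beyond the scatter, with at most a small move toward a higher number. Compound 3 is therefore estimated at 50 ug/mL in this assay, within a range of 25 ug/mL to 100 ug/mL. The step this implies, a 1.3-fold higher number from compound 2 to compound 3 (0.10 log units; within the scatter), is expected to stay within the usual scatter.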

Compound 3, half-maximal cytotoxic concentration: 55.3 ug/mL
Estimate against measurement, compound 3: 1.1-fold (0.04 log units) below, and the stated range covers the measured number.
By their numbers in this assay, from the lowest: compounds 2, 3 and 1 (each within the scatter of the next, the first and the last beyond it).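

In this assay, inverting the stereocentre at the saturated chain carbon, drawn R in compound 2 and S in compound 3, gives a 1.4-fold higher number from compound 2 to compound 3 (0.15 log units; within the scatter), so in these compounds the configuration at this position has no effect that can be separated from the scatter: the fact that compounds 2 and 3 differ only in the configuration as drawn. Methyl in place of hydrogen on a saturated chain carbon, three bonds along the chain from an aromatic carbon, gives a 1.6-fold lower number from compound 1 to compound 3 (0.21 log units; within the scatter), and this step also stays within the scatter. Compound 1 and compound 2 differ in both of these features, and although their printed values lie beyond the scatter of each other, neither single change taken alone accounts for that gap.

Going by these compounds, whether configuration at this stereocentre also leaves the number within the scatter when the chain is one methyl shorter, as in compound 1, remains open. Also open, on these data alone, is how this assay responds to a longer chain at this carbon, or to an amine or a carboxylic acid on the chain, where a single step might lie beyond the scatter.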